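The compounds below may be only part of what the source reports. "The series", "measured", "known", "first", "only" and "open" are said of these compounds alone.

In an assay on HEK293 cells for positive allosteric modulation of metabotropic glutamate receptor 5 (Homo sapiens), read by FLIPR (on this read-out higher numbers stand for an effect only at larger amounts of compound and lower numbers for an effect already at smaller amounts), compound 2 `CC1CCC(C(=O)N2CC(c3nc(-c4cccc(Cl)c4)no3)C2)CC1` gives 1500 nM, the higher of the two numbers shown. Compound 1 `O=C([C@H]1CC2CCC1C2)N1CC(c2nc(-c3ccccc3)no2)C1` gives 120 nM in this assay, a gap beyond the scatter. Compound 3 `Cc1ccc(S(=O)(=O)N2CC(c3nc(-c4cccc(Cl)c4)no3)C2)cc1` reaches only the limit of this assay, > 10000 nM; see (the limit of > 10000 nM in this assay, at which 1 of the 3 values shown sits). Compound 4 `O=C(C1CCCO1)N1CC(c2nc(-c3cccc(Cl)c3)no2)C1` is not yet measured; it differs from compound 2 by oxolan-2-yl in place of 4-methylcyclohexyl on a carbonyl carbon. Within the data shown here, no measured pair frames this change, so the expected step from compound 2 to compound 4 is a 1.7-fold higher number from compound 2 to compound 4 (0.22 log units; within the scatter), a small move toward a higher number that may not exceed the scatter. Compound 4 is estimated at 2500 nM in this assay, within 800 nM to 8000 nM.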

Compound 4, half-maximal effective concentration: > 10000 nM
Compound 4: a limit, no number; the forecaster's own chance of this, stated with the estimate: 15%; at least 4.0-fold (0.60 log units) between middle value and limit.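

Oxolan-2-yl in place of 4-methylcyclohexyl on a carbonyl carbon is not a neutral exchange in this assay: it gives an at least 6.6-fold higher number from compound 2 to compound 4 (0.82 log units; beyond the scatter). Among these compounds, this is the first step read at this position, and it shows that an amide-linked ring carrying one hydrogen-bond acceptor can fall out of the measurable range. Compound 4 gives a limit and not a number, so the step has no upper bound: the limit of > 10000 nM in this assay, at which 2 of the 4 values shown sit.

The change alters ring size and adds a ring oxygen in one move, and the compounds shown do not separate the two. Cyclopentyl on the same carbonyl carbon remains open as the group that would separate them.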